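This account rests on a few compounds, and the source may have more. Where it says the series, first, only, none or still open, it means among the compounds named here.

Compound 1 `CN(C[C@H]1Cc2c(cccc2N2C[C@@H]3C[C@H]2CN3)CN1)[C@H]1CCCc2cccnc21`: in a functional assay on CCRF-CEM cells for agonist activity at C-X-C chemokine receptor type 4 (Homo sapiens), read by calcium flux, with a stated time of 25 min (a lower number here means that less compound is needed, a higher number that more compound is needed for the effect), compound 1 gives > 30000 nM, which is a limit of the assay rather than a number.
Compound 2 `CN(C[C@H]1Cc2c(cccc2N2CCN(C3COC3)CC2)CN1)[C@H]1CCCc2cccnc21`: in this assay compound 2 gives > 30000 nM, again a limit of the assay.
Compound 3 `CN(C[C@H]1Cc2c(cccc2N2CCN3CCC[C@@H]3C2)CN1)[C@H]1CCCc2cccnc21`: in this assay compound 3 gives > 30000 nM, also a limit of the assay.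

Among the measured compounds shown here, compound 2 thus stands at the limit of this assay, and so do both other compounds measured so far (the limit of > 30000 nM in this assay, at which 3 of the 3 values shown sit). The three steps between them, a step that the two limits leave unreadable from compound 1 to compound 2, a step that the two limits leave unreadable from compound 1 to compound 3 and a step that the two limits leave unreadable from compound 2 to compound 3, therefore cannot be read: two limits give no size and no direction.

Compound 4 `CN(C[C@H]1Cc2c(cccc2N2CCN(c3ncccn3)CC2)CN1)[C@H]1CCCc2cccnc21` differs from compound 2 in one place: pyrimidin-2-yl in place of oxetan-3-yl on an amine nitrogen in a ring. The change sits on the same amine nitrogen in a ring that carried the oxetan-3-yl in compound 2. No measured step bears readably on this exchange, since every step shown joins two limits (the limit of > 30000 nM in this assay, at which 3 of the 3 values shown sit). For the measured compounds named here, the only guide is that all three measured compounds sit at the limit, so the most likely outcome for compound 4 is another limit, with no step beyond the scatter expected. The step from compound 2 is expected to be a number no higher from compound 2 to compound 4 (the limit leaves the size open). Compound 4 is accordingly estimated to give 30000 nM in this assay, with a range from 8000 nM to 100000 nM.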

Compound 4, half-maximal effective concentration: > 30000 nM
Compound 4 gave a limit, no number; the forecaster's own chance of this, stated with the estimate: 80%; the middle value lies on the limit itself.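

In this assay compound 4 gives > 30000 nM, which is a limit of the assay and not a number. The step from compound 2 to compound 4 therefore cannot be read, and the same holds for every pair so far: the limit of > 30000 nM in this assay, at which 4 of the 4 values shown sit. The compounds shown leave open how pyrimidin-2-yl and oxetan-3-yl truly compare, and which structure, if any, would give a measurable number.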